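A few compounds are considered here, and "the series" means these few. Any claim that something is new, unique, unknown or untested is made for them only; others in the source may bear on it.

The measured compounds and their numbers in a functional assay on CHO cells for agonist activity at Free fatty acid receptor 1 (Homo sapiens); on this read-out higher numbers stand for an effect only at larger amounts of compound and lower numbers for an effect already at smaller amounts:

compound 1, `Cc1nc(-c2ccc(C(F)(F)F)cc2)sc1CNc1ccc(OCC(=O)O)cc1`: 288 nM
compound 2, `CC(Cc1ccc(NCc2cccc(Oc3ccccc3)c2)cc1)C(=O)O`: 100 nM
compound 3, `Cc1nc(-c2ccc(C(F)(F)F)cc2)sc1CNc1ccc([C@H]2C[C@@H]2C(=O)NC2CCNC2)cc1`: 204 nM

Compound 2 shows the lowest of these three numbers; compound 3 lies beyond the scatter above it, and compound 1 lies further above still. Compound 4, `O=C(NO)[C@H]1C[C@@H]1c1ccc(NCc2cccc(Oc3ccccc3)c2)cc1`, differs from compound 2 in one place: 2-(hydroxycarbamoyl)cyclopropyl in place of 2-carboxypropyl on an aromatic carbon. Compound 4 shares the rest of its structure with compound 2.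

For the measured compounds named here, the one measured step that speaks to this kind of change is a 1.4-fold lower number from compound 1 to compound 3 (0.15 log units; within the scatter), in which the carboxymethoxy group gave way to a 2-((pyrrolidin-3-yl)carbamoyl)cyclopropyl group while the number stayed within the scatter. The present change also exchanges a chain bearing a carboxy group for a cyclopropyl bearing a carbonyl-containing group, so a comparably small movement is expected. Because a 1.4-fold lower number from compound 1 to compound 3 (0.15 log units; within the scatter) stayed within the scatter, the expected step in this assay is a 1.5-fold higher number from compound 2 to compound 4 (0.18 log units; within the scatter). Compound 4 is therefore estimated at 150 nM, with a range from 50 nM to 500 nM.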

Compound 4, half-maximal effective concentration: 14.8 nM
For compound 4 the middle estimate is 10-fold (1.01 log units) above the measured one; the measured number lies below the stated range.
By their numbers in this assay, from the lowest: compound 4; then compound 2; then compounds 3 and 1 (each within the scatter of the next).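

In this assay, for the compounds shown here, the group on the aromatic carbon para to a large group can strongly shift the number: a 6.8-fold lower number from compound 2 to compound 4 (0.83 log units; beyond the scatter) lies beyond the scatter, whereas the only earlier step of a similar kind, a 1.4-fold lower number from compound 1 to compound 3 (0.15 log units; within the scatter), stayed within it. Compound 4 carries 2-(hydroxycarbamoyl)cyclopropyl and no carboxy group, so on this shared core a carboxylic acid is not required for an effect at small amounts of compound. No available measurement explains why the number fell.

From the compounds shown here alone, this single step exchanges the open chain for a cyclopropyl ring and the carboxylic acid for a hydroxycarbamoyl group at once, so the contribution of each remains open. A cyclopropyl ring bearing a carboxylic acid, or an open propyl chain bearing a hydroxycarbamoyl group, would pull the two changes apart.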